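The compounds below may be only part of what the source reports. "The series", "measured", "known", "first", "only" and "open" are said of these compounds alone.

Measured so far in a functional assay on HT-1080 cells (Homo sapiens), read by transwell migration, with a stated time of 24 h, tested at 0.1 uM; a lower number here means a stronger effect, a higher number a weaker effect of the compound at the concentration tested: compound 1 `CC(=O)OCc1ccc2oc(=O)c(C(=O)Oc3cccc(Br)c3)cc2c1` gives 39.5%; compound 2 `CCCC(=O)OCc1ccc2oc(=O)c(C(=O)Oc3cccc(Br)c3)cc2c1` gives 88.6%.

Compound 2 stands highest of the two numbers, with compound 1 beyond the scatter below it. Compound 3 `CCCCC(=O)OCc1ccc2oc(=O)c(C(=O)Oc3cccc(Br)c3)cc2c1` differs from compound 2 by methyl in place of hydrogen on a saturated chain carbon, three bonds along the chain from a carbonyl carbon. Among the measured compounds shown here, the only measured step that bears on it is a number 49.1 percentage points higher from compound 1 to compound 2 (beyond the scatter), which reads, one bond further out, as ethyl to propyl; the present change reads as propyl to butyl. The numbers already sit high, so no step beyond the scatter is expected for compound 3 in this assay, an expected a number 1.4 percentage points higher from compound 2 to compound 3 (within the scatter). Compound 3 is therefore estimated at 90%, within 70% to 110%.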

Compound 3, a percentage reported as activity, at one concentration (the size of the read-out at that concentration, not a potency): 92.4%
Compound 3: the middle estimate sits 2.4 percentage points below what was measured; the range from low to high includes it.
By their numbers in this assay, from the lowest: compound 1; then compounds 2 and 3 (each within the scatter of the next).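

In this assay, going from propyl to butyl at this position gives a number 3.8 percentage points higher from compound 2 to compound 3 (within the scatter) and so does not repeat the large earlier step, which shows that the effect of lengthening this chain is not uniform across the three compounds. The large gap separates only the shortest chain from the others, as seen in a number 52.9 percentage points higher from compound 1 to compound 3 (beyond the scatter) and in the high values of both longer chains. Nothing available explains this pattern. Going by these compounds, it remains open whether a longer chain would stay as high, and whether an amine in place of the butyl group would bring the number back down.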